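From carboxy to sulfamoyl in a growth-inhibition series

A few compounds are considered here, and "the series" means these few. Any claim that something is new, unique, unknown or untested is made for them only; others in the source may bear on it.

Measured compounds:
compound 1 `CC(C)(C)CCOc1cccc(O)c1C(=O)/C=C/c1ccc(C(=O)O)cc1` — 4770 nM
compound 2 `O=C(/C=C/c1ccc(O)cc1)c1c(O)cccc1OCC1CCCC1` — 3160 nM
compound 3 `O=C(/C=C/c1ccc(O)cc1)c1c(O)cccc1OCCC1CCCCC1` — a limit only

Of the compounds shown here, three sharing one core have been tested in a functional assay on NCI-H23 cells (Homo sapiens) for antiproliferative activity, read by sulforhodamine B assay; on this read-out higher numbers stand for weaker inhibition of growth and lower numbers for stronger inhibition of growth. Compound 1 gives 4770 nM. Compound 2 gives 3160 nM. The two numbers lie within the scatter of one another, so neither can be called the more or the less active of the pair. For compound 3 the assay reports no number but only a limit, > 30000 nM; this is the limit of > 30000 nM in this assay, at which 1 of the 3 values shown sits.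

For the measured compounds named here, the one measured step, an at least 9.4-fold higher number from compound 2 to compound 3 (0.97 log units; beyond the scatter), concerns the saturated chain on the ether oxygen and not the group exchanged here.

Compound 4 `CC(C)(C)CCOc1cccc(O)c1C(=O)/C=C/c1ccc(S(N)(=O)=O)cc1` differs from compound 1 by sulfamoyl in place of carboxy on an aromatic carbon. Going by the values given here, no measured step in this set touches that position, so nothing here points to a move in either direction. Compound 4 is therefore expected to stay near compound 1, a 1.0-fold higher number from compound 1 to compound 4 (0.02 log units; within the scatter), with a wide allowance for uncertainty. In this assay compound 4 is estimated at 5000 nM, between 1500 nM and 20000 nM.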

Compound 4, concentration for 50% growth inhibition: 2950 nM
Beside the measured number, compound 4's estimate is 1.7-fold (0.23 log units) above it; measured number inside the range.
By their numbers in this assay, from the lowest: compounds 4, 2 and 1 (each within the scatter of the next). At a limit, above all of these: compound 3.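

In this assay, the exchange at this position gives a 1.6-fold lower number from compound 1 to compound 4 (0.21 log units; within the scatter), so compound 1 and compound 4 cannot be told apart on this read-out. For the compounds shown here, with the rest of the compound held constant, sulfamoyl in place of carboxy on an aromatic carbon, para to a large group, therefore gives a compound in the same range of growth inhibition, which the earlier compounds could not show because none of their steps touched this place. Nothing given here accounts for this outcome.

On these data alone, whether an amine, a nitrile or a methyl ester at this place would also stay in that range remains open. Also open, as far as these compounds go, is how the hydroxy group carried there by compound 2 compares with carboxy or sulfamoyl on an identical ether chain.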